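Methoxy for Methyl on Compound 2

The source may hold more compounds than are shown below. What is called first, only, known or untested is meant among the compounds shown, and "the series" means these compounds.

In a functional assay on PC-3 cells (Homo sapiens) for antiproliferative activity, read by MTT assay, with a stated time of 72 h (a lower number here means a stronger inhibitor, a higher number a weaker inhibitor), compound 1 (`COc1ccc(NC(=S)Nc2nc(C(=O)NCc3ccccc3)cs2)cc1`) gives 39300 nM and compound 2 (`CCOC(=O)c1csc2nc(CN3CCN(C)CC3)c(-c3ccc(C)cc3)n12`) gives 65000 nM. These two values lie within the usual scatter of each other, so compound 2 stands level with compound 1 among the numbers available. For compound 3 (`CCOC(=O)c1csc2nc(CN3CCN(Cc4ccccc4)CC3)c(-c3ccc(C)cc3)n12`), this assay reports only a limit, > 100000 nM.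

Compound 4 (`CCOC(=O)c1csc2nc(CN3CCN(C)CC3)c(-c3ccc(OC)cc3)n12`) has not yet been measured. It differs from compound 2 by methoxy in place of methyl on an aromatic carbon, that is, 4-methylphenyl to 4-methoxyphenyl. Within the data shown here, only one measured step starts from compound 2, and it offers little guidance here. That step, an at least 1.5-fold higher number from compound 2 to compound 3 (0.18 log units; that floor lies within the scatter), places phenyl in place of hydrogen on a saturated chain carbon bound to an amine nitrogen in a ring, which is a different part of the molecule. Among the measured compounds shown here, no measured step changes the aromatic carbon involved here, so no shift beyond the scatter is expected in this assay, and neither direction is favoured. The expected step is a 1.1-fold lower number from compound 2 to compound 4 (0.03 log units; within the scatter). Compound 4 is estimated at 60000 nM, with an expected range from 25000 nM to 100000 nM.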

Compound 4, half-maximal inhibitory concentration: 69400 nM
The estimate for compound 4 lay 1.2-fold (0.06 log units) below the measured number; low and high end bracket the measured number.
By their numbers in this assay, from the lowest: compounds 1, 2 and 4 (each within the scatter of the next). At a limit, above all of these: compound 3.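

In this assay, the replacement of 4-methylphenyl by 4-methoxyphenyl is the only step shown at this aromatic carbon, para to a large group, and it gives a 1.1-fold higher number from compound 2 to compound 4 (0.03 log units; within the scatter). Methoxy brings 2 heavy atoms and 1 hydrogen-bond acceptor where methyl brings 1 heavy atom and no acceptor, yet in this assay this difference leaves compound 4 level with compound 2, so this one change at this position shows no measurable effect. Both compounds give real numbers and can be compared directly, unlike compound 3, which is reported only as a limit: the limit of > 100000 nM in this assay, at which 1 of the 4 values shown sits.

Going by these compounds, whether a group of another kind on this aromatic carbon, such as an amine, a carboxylic acid or a longer alkoxy chain, would move the number beyond the scatter remains open. On these data alone, it is also open whether methoxy in place of methyl would read the same on the core of compound 3, which carries the added phenyl, or whether any change here could bring these compounds close to a strong inhibitor.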